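The source may report more compounds than this note shows. Statements on the series, on what has been measured and on what is new or still open speak of the compounds shown alone.

Working notes on the series. In a functional assay on K562 cells (Homo sapiens) for antiproliferative activity, read by CellTiter-Glo and CCK-8 assay, with a stated time of 72 h (on this read-out lower numbers stand for stronger inhibition of growth and higher numbers for weaker inhibition of growth), compound 1 `Cc1ccc(Oc2ncc3c(n2)N(C)C(=O)N(c2cc(NC(=O)c4cccc(C(F)(F)F)c4)ccc2C)C3)cc1N` gives 13 nM. Compound 2 `CNc1nc(Nc2ccc(C)c([N+](=O)[O-])c2)ncc1C(=O)Nc1cc(NC(=O)c2cccc(OC)c2)ccc1C` gives 480 nM in this assay, the higher of the two numbers recorded so far, and the gap between compound 2 and compound 1 lies beyond the scatter. Compound 3 `CNc1nc(Nc2ccc(C)c([N+](=O)[O-])c2)ncc1C(=O)Nc1cc(NC(=O)c2cc(OC)cc(OC)c2)ccc1C` has not yet been measured in this assay. It differs from compound 2 by methoxy in place of hydrogen on an aromatic carbon. Among the measured compounds shown here, no measured pair in the set shows this kind of change, so no direction can be read from the data. The second methoxy on that ring is expected to move the number only slightly, and a step from compound 2 to compound 3 of a 1.1-fold lower number from compound 2 to compound 3 (0.06 log units; within the scatter) is expected, within the scatter. For compound 3 the estimate in this assay is 420 nM, with a range from 150 nM to 1200 nM.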

Compound 3, concentration for 50% growth inhibition: 1070 nM
Estimate against measurement, compound 3: 2.5-fold (0.41 log units) below, within the range that was stated.
By their numbers in this assay, from the lowest: compound 1; then compound 2; then compound 3.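

Working notes, continued. In this assay, among the compounds shown here, the change from 3-methoxyphenyl to 3,5-dimethoxyphenyl on the carbonyl gives the first step between compounds that differ in one place (a 2.2-fold higher number from compound 2 to compound 3 (0.35 log units; beyond the scatter)). For the compounds shown here, the second methoxy therefore raises the number at this place on the ring, a modest loss of growth inhibition and a direction that no earlier pair could show. Nothing at hand accounts for this step.

Going by these compounds, the effect of an amine, a hydroxyl group or a longer alkoxy chain at this place remains open. On these data alone, compound 1 differs from compound 2 in more than one place, so it also remains open how much of their gap belongs to this ring and how much to the core.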